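This account rests on a few compounds, and the source may have more. Where it says the series, first, only, none or still open, it means among the compounds named here.

Working notes on the series. Compound 1, `COc1ccc(C2OC(c3cc(OC)c(OC)c(OC)c3)=NN2C(C)=O)c(OC)c1`, gives 69.5% in a functional assay on PC-3 cells (Homo sapiens) for antiproliferative activity, read by MTT assay, tested at 1 uM; on this read-out higher numbers stand for a stronger effect at the one concentration tested and lower numbers for a weaker effect. Among the measured compounds shown here, compound 2, `COc1cc(C2=NN(C(C)=O)C(c3ccc(Cl)c(Cl)c3)O2)cc(OC)c1OC`, gives 28.1% in this assay; the one measured step, a number 41.4 percentage points lower from compound 1 to compound 2 (beyond the scatter), is the only change at the saturated ring carbon on record, and it leaves compound 2 as the lowest of the two numbers, with compound 1 the nearer and higher one.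

Compound 3, `COc1cc(C2=NN(C(C)=O)C(c3ccc(C(F)(F)F)cc3)O2)cc(OC)c1OC`, is not yet measured. It differs from compound 2 by 4-(trifluoromethyl)phenyl in place of 3,4-dichlorophenyl on a saturated ring carbon. For the measured compounds named here, no measured pair exchanges one substituted phenyl for another at this saturated ring carbon, so no step bears directly on the move. The step from compound 1 to compound 2 bears only in showing that a change at this carbon can move the read-out in this assay by a large amount, in either direction for all that is known. Going by the values given here, with one step and no matching pair, the expectation for compound 3 is a step of a number 1.9 percentage points higher from compound 2 to compound 3 (within the scatter) in this assay, that is none beyond the scatter, around the value of compound 2 with a wide range. Compound 3 is thus estimated at 30%, with a range of 10% to 60%.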

Compound 3, a percentage reported as inhibition, at one concentration (the size of the read-out at that concentration, not a potency): -11%
Estimate against measurement, compound 3: 41 percentage points above; measured number outside the range, below it.
By their numbers in this assay, from the lowest: compound 3; then compound 2; then compound 1.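

In this assay, the exchange of one substituted phenyl for another at the saturated ring carbon is now on record, and it is not neutral: a number 39.1 percentage points lower from compound 2 to compound 3 (beyond the scatter), with 4-(trifluoromethyl)phenyl in place of 3,4-dichlorophenyl, so the read-out at this carbon depends on what the phenyl carries and not only on a phenyl being there. Compound 3 gives -11%, a number below zero, and the widest step at this carbon is now a number 80.5 percentage points lower from compound 1 to compound 3 (beyond the scatter), with 4-(trifluoromethyl)phenyl in place of 2,4-dimethoxyphenyl, so both replacements of 2,4-dimethoxyphenyl on record go downward and beyond the scatter. Nothing at hand accounts for these differences.

Compound 2 and compound 3 differ at once in the kind of substituent and in where it sits on the phenyl, so the two changes cannot be told apart from these three compounds. On these data alone, how plain phenyl, or a phenyl carrying an amine or a carboxylic acid, would fall in this order remains open, as does whether the same order holds with any other group in place of the acetyl group.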